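The compounds below may be only part of what the source reports. "The series", "measured", "known", "first", "only" and "open" are said of these compounds alone.

Compound 3, `CCCOc1nc(N)c2nc(O)n(Cc3ccccc3)c2n1`, gives 0.01 uM in a functional assay (spleen, spleen) for activation, with Mus musculus as the target; a lower number here means that less compound is needed, a higher number that more compound is needed for the effect. That figure is level with compound 1, `CCCSc1nc(N)c2nc(O)n(Cc3ccccc3)c2n1`, which gives 0.01 uM, the two together the lowest of the three numbers; the move no change at the digits printed from compound 1 to compound 3 (within the scatter) shows how little separates them. Compound 2, `CCOc1nc(N)c2nc(O)n(Cc3ccccc3)c2n1`, gives 0.1 uM, and the move a 10-fold lower number from compound 2 to compound 3 (1.00 log units; beyond the scatter) sets compound 3 apart from it.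

Compound 4 is `Nc1nc(S)nc2c1nc(O)n2Cc1ccccc1`; it differs from compound 3 by sulfanyl in place of propoxy on an aromatic carbon. Two measured steps speak to this change. The swap of sulfur for oxygen at the same aromatic carbon, no change at the digits printed from compound 1 to compound 3 (within the scatter), stayed within the scatter, so the heteroatom itself hardly matters here. The chain, by contrast, does: taking away one carbon, a 10-fold lower number from compound 2 to compound 3 (1.00 log units; beyond the scatter) read in reverse, cost a modest but clear amount, and compound 4 gives up the whole chain, leaving only sulfanyl. Compound 4 is therefore expected to need more compound, a step of a 100-fold higher number from compound 3 to compound 4 (2.00 log units; beyond the scatter). The estimate for compound 4 is 1 uM, within a range of 0.1 uM to 10 uM.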

Compound 4, minimum effective concentration: 10 uM
For compound 4 the middle estimate is 10-fold (1.00 log units) below the measured one; the measured number falls inside the stated range.
By their numbers in this assay, from the lowest: compounds 1 and 3 (each within the scatter of the next); then compound 2; then compound 4.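

In this assay the loss on removing the whole chain goes well beyond the cost of shortening it, with a 1000-fold higher number from compound 3 to compound 4 (3.00 log units; beyond the scatter) and, where only the propyl on the sulfur gives way to hydrogen, a 1000-fold higher number from compound 1 to compound 4 (3.00 log units; beyond the scatter) for the same change at this aromatic carbon. Even the shorter ethoxy group stands clearly apart from the bare sulfanyl, with a 100-fold higher number from compound 2 to compound 4 (2.00 log units; beyond the scatter) showing that, among these four compounds, a sulfur alone at this position does not reproduce what an alkyl chain on the heteroatom gives. Nothing measured here accounts for the size of this loss.

The compounds shown leave open how the number moves with a methoxy or methylsulfanyl group, the step just above the bare sulfanyl. They also leave open whether a longer chain such as butoxy, or an amine at this carbon, would hold the level of compound 3.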